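Positional shift of the trifluoromethyl group on the aryl arm

The source may report more compounds than this note shows. Statements on the series, on what has been measured and on what is new or still open speak of the compounds shown alone.

The series shares one core carrying a 2-hydroxyphenyl group and a 3-hydroxyphenyl group; compound 1 `Oc1cccc(-c2cc(-c3ccccc3F)cc(-c3ccccc3O)n2)c1` adds a 2-fluorophenyl group and compound 2 `Oc1cccc(-c2cc(-c3cccc(C(F)(F)F)c3)cc(-c3ccccc3O)n2)c1` a 3-(trifluoromethyl)phenyl group. In a functional assay on T47D cells (Homo sapiens) for inhibition (on this read-out lower numbers stand for stronger inhibition and higher numbers for weaker inhibition), compound 1 gives 24200 nM and compound 2 gives 6340 nM. Going by the values given here, the only measured step so far is a 3.8-fold lower number from compound 1 to compound 2 (0.58 log units; beyond the scatter), so compound 2 holds the lower of the two numbers and stands apart from compound 1 by more than the scatter. Compound 3 `Oc1cccc(-c2cc(-c3ccc(C(F)(F)F)cc3)cc(-c3ccccc3O)n2)c1` has not been measured. Its difference from compound 2 is 4-(trifluoromethyl)phenyl in place of 3-(trifluoromethyl)phenyl on an aromatic carbon. Among the compounds with values here, no measured step bears directly on this change: the one step in hand alters both the substituent and its ring position at once and cannot be split into a part for each. With no separate reading of ring position available, compound 3 is expected to show a step of about a 1.1-fold lower number from compound 2 to compound 3 (0.02 log units; within the scatter), that is nothing clearly beyond the scatter. Compound 3 is therefore estimated at around 6000 nM, within a range of 2500 nM to 15000 nM.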

Compound 3, half-maximal inhibitory concentration: > 50000 nM
Compound 3: a limit, no number; the forecaster's own chance of this, stated with the estimate: 5%; at least 8.3-fold (0.92 log units) between middle value and limit.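

For compound 3 the read-out in this assay is a limit and not a number: the limit of > 50000 nM in this assay, at which 1 of the 3 values shown sits.

Moving the trifluoromethyl group within the aryl arm, with the atoms otherwise unchanged, gives an at least 7.8-fold higher number from compound 2 to compound 3 (0.89 log units; beyond the scatter), so ring position on this arm matters on its own in a way the earlier pair could not show. Exchanging 2-fluorophenyl for 4-(trifluoromethyl)phenyl gives an at least 2.0-fold higher number from compound 1 to compound 3 (0.31 log units; beyond the scatter), which runs opposite to the step from compound 1 to compound 2, so the lower number of compound 2 belongs to 3-(trifluoromethyl)phenyl and not to a trifluoromethyl-bearing aryl arm in general.

Open, on these data alone, is whether 4-chlorophenyl or 4-methoxyphenyl at the same carbon would behave as 4-(trifluoromethyl)phenyl does, which would separate a reading tied to ring position from one tied to the trifluoromethyl group itself. Equally open, as far as these compounds go, is whether an amine or a carboxylic acid in place of the trifluoromethyl group would keep the number of compound 2 or lose it as compound 3 does.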